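Swapping 3,5-dimethoxyphenyl for 4-fluorophenyl in compound 2

The source may report more compounds than this note shows. Statements on the series, on what has been measured and on what is new or still open speak of the compounds shown alone.

In a functional assay on A549 cells (Homo sapiens) for cytotoxicity, read by MTT assay, with a stated time of 72 h (a higher number here means a weaker inhibitor, a lower number a stronger inhibitor), compound 2 (`COc1cc(Nc2nc3ccccc3nc2S(=O)(=O)c2ccc(Br)cc2)cc(OC)c1`) gives 15900 nM, the middle of three numbers. Compound 1 (`Cc1ccc(S(=O)(=O)c2nc3ccccc3nc2Nc2ccc(F)cc2)cc1`) lies higher at 39200 nM, and compound 3 (`COc1cc(Nc2nc3ccccc3nc2S(=O)(=O)c2ccc(Br)cc2)cc(OC)c1OC`) lies lower at 6110 nM. Compound 4 (`O=S(=O)(c1ccc(Br)cc1)c1nc2ccccc2nc1Nc1ccc(F)cc1`) differs from compound 2 in one place: 4-fluorophenyl in place of 3,5-dimethoxyphenyl on a nitrogen on an aromatic ring. Among the compounds with values here, the only measured step touching this group is a 2.6-fold lower number from compound 2 to compound 3 (0.42 log units; beyond the scatter), where methoxy in place of hydrogen on an aromatic carbon gave a modest drop. Losing the methoxy groups should therefore raise the number modestly. Compound 1, which also carries 4-fluorophenyl but differs elsewhere, points the same way at 39200 nM. The expected change is a 2.1-fold higher number from compound 2 to compound 4 (0.33 log units; beyond the scatter). For compound 4 the estimated value is 34000 nM, with an expected range from 15000 nM to 70000 nM.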

Compound 4, half-maximal inhibitory concentration: 4360 nM
Compound 4: middle estimate off by 7.8-fold (0.89 log units), on the high side; measured number outside the range, below it.
By their numbers in this assay, from the lowest: compounds 4 and 3 (each within the scatter of the next); then compound 2; then compound 1.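

In this assay, 4-fluorophenyl in place of 3,5-dimethoxyphenyl gives a 3.6-fold lower number from compound 2 to compound 4 (0.56 log units; beyond the scatter), so methoxy groups are not required on this ring for a low number. With 4-fluorophenyl held fixed, bromo in place of methyl gives a 9.0-fold lower number from compound 1 to compound 4 (0.95 log units; beyond the scatter), the largest step shown, so the high number of compound 1 did not predict how 4-fluorophenyl would behave alongside bromo. Nothing available explains either step. Still open, as far as these compounds go, is how a chloro group or an amine in place of the fluoro on this ring would read, and whether methyl in place of bromo has the same effect with 3,5-dimethoxyphenyl on the nitrogen.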